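This account rests on a few compounds, and the source may have more. Where it says the series, first, only, none or still open, it means among the compounds named here.

Measured so far in a functional assay on cells for agonist activity at Free fatty acid receptor 1 (Mus musculus), read by FLIPR and calcium flux, with a stated time of 5 min; a higher number here means a larger maximal response, a lower number a smaller maximal response:
compound 1, `COc1nn(-c2ccccn2)c2cc(-c3ccc(CCC(=O)O)cc3)ccc12`: compound 1 gives 96%
compound 2, `Cc1nn(-c2ccccn2)c2cc(-c3ccc([C@H]4C[C@@H]4C(=O)O)cc3)ccc12`: compound 2 gives 6%; 10% (2 entries)
compound 3, `COc1nn(-c2ccccn2)c2cc(-c3ccc([C@H]4C[C@@H]4C(=O)O)cc3)cc(F)c12`: compound 3 gives 19%

Compound 3 stands at the lower of the two single numbers in this assay; the nearest, compound 1, sits higher by a gap beyond the scatter. Compound 2 is represented only by several entries, (the several entries of compound 2 in this assay, 6%; 10% (2 entries)), all of which fall below compound 3 on the face of it, though no single number is given for it. Within the data shown here, the series so far shows the largest maximal response with the propanoic acid of compound 1 and small responses with the cyclopropane acids of compound 2 and compound 3.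

Compound 4, `COc1nn(-c2ccccn2)c2cc(-c3ccc([C@H]4C[C@@H]4C(=O)O)cc3)ccc12`, differs from compound 3 in one place: hydrogen in place of fluoro on an aromatic carbon. Among the measured compounds shown here, no measured pair isolates this change, so its effect must be inferred. Compound 4 keeps the cyclopropane acid of compound 3 and compound 2, both low in this assay, and the methoxy of compound 1. A modest rise is expected, a number 11 percentage points higher from compound 3 to compound 4 (beyond the scatter), but not one reaching compound 1. The estimate for compound 4 is 30%, with a range expected from 10% to 65%.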

Compound 4, largest response reached (reported as efficacy), in percent of the reference or control that the assay uses: 1%
Compound 4: middle estimate off by 29 percentage points, on the high side; the whole stated range lies above it.
By their numbers in this assay, from the lowest: compound 4; then compound 3; then compound 1.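

In this assay, among these compounds, hydrogen in place of fluoro on this aromatic carbon gives a number 18 percentage points lower from compound 3 to compound 4 (beyond the scatter), so in the cyclopropane acid series the response falls when the fluoro leaves rather than rising. 2-Carboxycyclopropyl in place of 2-carboxyethyl gives a number 95 percentage points lower from compound 1 to compound 4 (beyond the scatter), a large step against the modest one at the fluoro position, and this pair isolates the acid side chain as a single change for the first time. Compound 2, with methyl in place of the methoxy of compound 4, also stays low: the several entries of compound 2 in this assay, 6%; 10% (2 entries)

On these data alone, whether a fluoro on this aromatic carbon would shift the response of the propanoic acid of compound 1 remains open. Also open, as far as these compounds go, is what a chloro or a nitrile at this place, or a longer chain such as a butanoic acid in place of the 2-carboxyethyl, would give.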